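The compounds below may be only part of what the source reports. "The series", "measured", "known", "first", "only" and "open" are said of these compounds alone.

Measured so far in a toxicity assay on NIH3T3 cells (Mus musculus) for cytotoxicity, read by resazurin assay; a lower number here means that less compound is needed, a higher number that more compound is needed for the effect:
- compound 1 `COC(=O)c1ccc(NCc2cncn2Cc2cccc(OC)c2)cc1-c1ccccc1`: "not determined" (no result reported)
- compound 2 `COC(=O)c1ccc(NCc2cncn2Cc2ccccc2OC)cc1-c1ccccc1`: "not determined" (no result reported)
- compound 3 `COC(=O)c1ccc(NCc2cncn2Cc2ccccc2C#N)cc1-c1ccccc1`: 25000 nM

For the measured compounds named here, compound 3 carries the only number in this assay, at 25000 nM. With no result for compound 1 or compound 2, it cannot be ranked against either. The next compound is compound 4 `COC(=O)c1ccc(NCc2cncn2Cc2ccc(F)cc2F)cc1-c1ccccc1`. Its change from compound 3 is 2,4-difluorophenyl in place of 2-cyanophenyl on a saturated chain carbon bound to an aromatic nitrogen. Going by the values given here, the series offers no measured step to size this change, so the expectation rests on the single value of compound 3 and carries a wide range. No shift beyond the scatter is expected, and no direction is favoured. The estimated step, a 1.3-fold lower number from compound 3 to compound 4 (0.10 log units; within the scatter), stays within the scatter. Compound 4 is expected at 20000 nM, with an estimated range of 8000 nM to 50000 nM.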

Compound 4, half-maximal effective concentration: > 1000 nM
Compound 4 gave a limit, no number (the forecaster's own chance of this, stated with the estimate: 25%); the middle value is on the limit's open side.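

In this assay, for the compounds shown here, compound 4 gives > 1000 nM which is a limit and not a number, so no step from compound 3 to compound 4 can be read. The compounds shown leave open whether 2,4-difluorobenzyl in place of 2-cyanobenzyl shifts the half-maximal effective concentration at all.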